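Fluoro for methoxy: cytotoxicity notes on the series

This account rests on a few compounds, and the source may have more. Where it says the series, first, only, none or still open, it means among the compounds named here.

Among the compounds with values here, compound 2 `CCCC[C@H](CCn1cncn1)c1ccc(OC)cc1` stands at 34.5 ug/mL in an ADME assay on HEp-2 cells (Homo sapiens) for cytotoxicity, read by MTT assay, with a stated time of 3 days; a lower number here means that less compound is tolerated, a higher number that more compound is tolerated; its only measured neighbour, compound 1 `CCCC[C@H](CCn1cncn1)c1ccccc1`, gives 50.2 ug/mL, and the step of a 1.5-fold lower number from compound 1 to compound 2 (0.16 log units; within the scatter) lies within the scatter. Compound 3 `CCCC[C@H](CCn1cncn1)c1ccc(F)cc1` brings a different change at the same aromatic carbon: fluoro in place of methoxy on an aromatic carbon. Within the data shown here, no measured step exchanges one group for another there, so the single methoxy-for-hydrogen step, itself within the scatter, is all that bears on it. For compound 3 a step of a 1.2-fold higher number from compound 2 to compound 3 (0.06 log units; within the scatter) is therefore expected, nothing beyond the scatter. Compound 3 is estimated at 40 ug/mL, with a range from 20 ug/mL to 80 ug/mL.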

Compound 3, half-maximal cytotoxic concentration: 38.5 ug/mL
For compound 3 the middle estimate is 1.0-fold (0.02 log units) above the measured one; the range from low to high includes it.
By their numbers in this assay, from the lowest: compounds 2, 3 and 1 (each within the scatter of the next).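

Fluoro in place of methoxy gives a 1.1-fold higher number from compound 2 to compound 3 (0.05 log units; within the scatter) in this assay and fluoro in place of hydrogen gives a 1.3-fold lower number from compound 1 to compound 3 (0.12 log units; within the scatter) in the same read-out. Hydrogen, methoxy and fluoro on this aromatic carbon, para to a large group, therefore cannot be told apart here, whereas the earlier compounds offered only the hydrogen and methoxy pair. No supporting measurement bears on this result. Still open, as far as these compounds go, is whether an amine or a carboxylic acid on this carbon would give a step beyond the scatter. From the compounds shown here alone, the effect of a longer chain on the shared core also remains open.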